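Trifluoroethoxy to methoxy: one step seen, one step expected

The source may hold more compounds than are shown below. What is called first, only, known or untested is meant among the compounds shown, and "the series" means these compounds.

Compound 2 `O=C(NNc1nncc2ccccc12)C1CC1c1ccc(OCC(F)(F)F)cc1` and compound 1 `COc1ccc(C2CC2C(=O)NNc2nncc3ccccc23)cc1` share a core and differ in a single place: hydrogen in place of trifluoromethyl on a saturated chain carbon bound to an oxygen on an aromatic ring. In a functional assay on U-373MG ATCC cells (Homo sapiens) for inhibition, read by MTT assay, with a stated time of 72 h (a higher number here means a weaker inhibitor, a lower number a stronger inhibitor), compound 2 gives 25000 nM, while compound 1 gives 83000 nM, a step of a 3.3-fold higher number from compound 2 to compound 1 (0.52 log units; beyond the scatter). Compound 3 `O=C(NNC(=O)C1CC1c1ccc(OCC(F)(F)F)cc1)c1ccncc1` carries a different core; the difference between the two cores is not broken down here. In this assay compound 3 gives 19000 nM, which lies within the usual scatter of the value of compound 2. Compound 4 `COc1ccc(C2CC2C(=O)NNC(=O)c2ccncc2)cc1` differs from compound 3 by the same change: hydrogen in place of trifluoromethyl on a saturated chain carbon bound to an oxygen on an aromatic ring. Within the data shown here, the step from compound 3 to compound 4 is expected to be a 3.2-fold higher number from compound 3 to compound 4 (0.50 log units; beyond the scatter), resting on the single earlier step of a 3.3-fold higher number from compound 2 to compound 1 (0.52 log units; beyond the scatter) on the other core. Among the measured compounds shown here, compound 4 is therefore estimated at 60000 nM, with a range from 25000 nM to 150000 nM reflecting that only one prior example exists.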

Compound 4, half-maximal inhibitory concentration: > 100000 nM
Compound 4: a limit, no number; the forecaster's own chance of this, stated with the estimate: 20%; middle value at least 1.6-fold (0.22 log units) away from the limit.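

In this assay compound 4 gives > 100000 nM, which is a limit of the assay and not a number. Replacing 2,2,2-trifluoroethoxy with methoxy on this second core gives an at least 5.2-fold higher number from compound 3 to compound 4 (0.72 log units; beyond the scatter), so the number rises with this change on both cores shown. This shows that the direction of the step carried over from one core to the other, but it does not show that its size did: the same change on two cores in this assay, a 3.3-fold higher number (0.52 log units; beyond the scatter) from compound 2 to compound 1 and an at least 5.2-fold higher number (0.72 log units; beyond the scatter) from compound 3 to compound 4; the limit leaves it open whether they differ

The compounds shown carry only 2,2,2-trifluoroethoxy and methoxy at this place, so it remains open how an ethoxy group or a longer chain would read here. As far as these compounds go, whether the same direction would hold on a third core also remains open.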